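Shifting a Hydroxyphenyl Group: Expected Loss of Inhibition

A few compounds are considered here, and "the series" means these few. Any claim that something is new, unique, unknown or untested is made for them only; others in the source may bear on it.

Compound 1, `Oc1ccc(-c2cc(-c3ccc(C(F)(F)F)cc3)cc(-c3cccc(O)c3)n2)cc1`, gives 2870 nM in a functional assay on T47D cells (Homo sapiens) for inhibition; a higher number here means a weaker inhibitor, a lower number a stronger inhibitor.
Compound 2, `Oc1ccc(-c2cc(-c3ccc(C(F)(F)F)cc3)cc(-c3ccc(O)cc3)n2)cc1`, gives only a limit in this assay, > 50000 nM.
Compound 3, `Oc1cccc(-c2cc(-c3cccc(OC(F)(F)F)c3)cc(-c3ccccc3O)n2)c1`, gives 5390 nM in this assay.

The step from compound 1 to compound 2 is 4-hydroxyphenyl in place of 3-hydroxyphenyl on an aromatic carbon. It brought an at least 17-fold higher number from compound 1 to compound 2 (1.24 log units; beyond the scatter), and the size of that step is tied to the limit of > 50000 nM in this assay, at which 1 of the 3 values shown sits. Compound 4, `Oc1ccc(-c2cc(-c3cccc(OC(F)(F)F)c3)cc(-c3ccccc3O)n2)cc1`, is not yet measured. It is related to compound 3 by 4-hydroxyphenyl in place of 3-hydroxyphenyl on an aromatic carbon, the same kind of change, though the surroundings differ: in compound 1 the place is meta to a 4-(trifluoromethyl)phenyl group and meta to a 4-hydroxyphenyl group, while in compound 3 it is meta to a 2-hydroxyphenyl group and meta to a large group. The difference between the two cores of compound 1 and compound 3 is not broken down here. Compound 3 and compound 1 give numbers within the usual scatter of each other. Given the step of compound 1 to compound 2, compound 4 is expected to show a 9.3-fold higher number from compound 3 to compound 4 (0.97 log units; beyond the scatter). Compound 4 is estimated at 50000 nM, between 15000 nM and 200000 nM, and it may well come back as a limit.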

Compound 4, half-maximal inhibitory concentration: > 50000 nM
Compound 4: no number, only a limit (the forecaster's own chance of this, stated with the estimate: 55%); the middle value sits exactly at the limit.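

Moving the hydroxyl group from the 3-hydroxyphenyl to the 4-hydroxyphenyl arrangement also weakens inhibition on the second core, with an at least 9.2-fold higher number from compound 3 to compound 4 (0.96 log units; beyond the scatter) in this assay, so the loss seen on the core of compound 1 carries over to the core of compound 3. This shows the direction of the change holding on two cores, but not that its size is the same on both, since each step is only a lower bound: the same change on two cores in this assay, an at least 17-fold higher number (1.24 log units; beyond the scatter) from compound 1 to compound 2 and an at least 9.2-fold higher number (0.96 log units; beyond the scatter) from compound 3 to compound 4; the limit leaves it open whether they differ Compound 4 gives only a limit rather than a number, and the same limit caps both steps: the limit of > 50000 nM in this assay, at which 2 of the 4 values shown sit.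

The compounds shown leave open how far inhibition really falls on either core, and whether the same loss would appear on a third core. They also leave open whether an amine or a carboxylic acid on that phenyl ring, in place of the hydroxyl group, would be tolerated any better at the 4-position than the hydroxyl group is.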